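Working notes on a cytotoxicity series, compound 2 to compound 4

The source may hold more compounds than are shown below. What is called first, only, known or untested is meant among the compounds shown, and "the series" means these compounds.

Measured so far:
compound 1 `Cc1nc(C(=O)NCc2ccccc2)c(O)c(=O)n1C`: in an ADME assay on HepG2 cells (Homo sapiens) for cytotoxicity, in the presence of a further agent that is not named here (on this read-out higher numbers stand for weaker inhibition and lower numbers for stronger inhibition), compound 1 gives only a limit, > 100000 nM
compound 2 `Cn1c(Cc2ccccc2C(F)(F)F)nc(C(=O)Nc2ccccc2)c(O)c1=O`: in this assay compound 2 gives only a limit, > 100000 nM
compound 3 `COc1nc(C(C)c2ccccc2C(F)(F)F)nc(C(=O)NCc2ccccc2)c1O`: in this assay compound 3 gives only a limit, > 100000 nM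

Every value shown sits at the limit of > 100000 nM in this assay, at which 3 of the 3 values shown sit. Compound 2 therefore stands at the limit together with the other two compounds, and no ordering among them can be read. For the measured compounds named here, no step between measured compounds exists in this set.

Compound 4 `CC(NC(=O)c1nc(Cc2ccccc2C(F)(F)F)n(C)c(=O)c1O)c1ccccc1` differs from compound 2 by 1-phenylethyl in place of phenyl on an amide-type nitrogen. Going by the values given here, with no measured step to draw on, the expected change a number no higher from compound 2 to compound 4 (the limit leaves the size open) is none beyond the usual scatter. Compound 4 is expected to give 100000 nM, with a range from 40000 nM to 250000 nM, most probably reported again only as a limit.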

Compound 4, half-maximal inhibitory concentration: > 100000 nM
Compound 4 was reported as a limit; the forecaster's own chance of this, stated with the estimate: 85%; the middle value lies on the limit itself.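

No step can be read from compound 2 to compound 4, as both values are only limits: the limit of > 100000 nM in this assay, at which 4 of the 4 values shown sit. The compounds shown leave open whether 1-phenylethyl in place of phenyl changes cytotoxicity at all.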